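Methylation of the carbamoyl nitrogen: compound 2 to compound 4

This account rests on a few compounds, and the source may have more. Where it says the series, first, only, none or still open, it means among the compounds named here.

In a functional assay on MCF7 cells (Homo sapiens) for antiproliferative activity, read by CCK-8 assay, with a stated time of 72 h (on this read-out higher numbers stand for weaker inhibition of growth and lower numbers for stronger inhibition of growth), compound 1 `CCCNS(=O)(=O)c1ccc(Nc2ncc3c(n2)N(C2CCCC2)[C@H](CC)C(=O)N3C)cc1` gives 344 nM, and compound 3 `CC[C@@H]1C(=O)N(C)c2cnc(Nc3ccc(S(=O)(=O)NCCO)cc3)nc2N1C1CCCC1` gives 344 nM; no change at the digits printed from compound 1 to compound 3 (within the scatter). Compound 2 `CCC1C(=O)N(C)c2cnc(-n3ccc4cc(C(N)=O)ccc43)nc2N1c1ccn(C)n1` is reported in this assay as "not active" (no number reported), that is, without growth inhibition and with no number given. Compound 4 `CCC1C(=O)N(C)c2cnc(-n3ccc4cc(C(=O)NC)ccc43)nc2N1c1ccn(C)n1` differs from compound 2 by methyl in place of hydrogen on an amide-type nitrogen. Within the data shown here, the single measured step concerns the sulfonamide side chain and does not bear on an amide nitrogen, so no measured step sizes this change, and with compound 2 giving no number the step to compound 4 cannot be quantified. Compound 4 is therefore expected to remain weak in this assay, estimated at 20000 nM with a range of 3000 nM to 100000 nM, and a limit rather than a number may again be reported.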

Compound 4, concentration for 50% growth inhibition: 35400 nM
Compound 4: the middle estimate sits 1.8-fold (0.25 log units) below what was measured; low and high end bracket the measured number.
By their numbers in this assay, from the lowest: compounds 1 and 3 (each within the scatter of the next); then compound 4.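

No step can be read from compound 2 to compound 4 in this assay: compound 2 has no number, while compound 4 gives 35400 nM. As far as these compounds go, what methyl on the amide-type nitrogen contributes remains open. No evidence bears on this result.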